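A few compounds are considered here, and "the series" means these few. Any claim that something is new, unique, unknown or untested is made for them only; others in the source may bear on it.

Compound 1 `Cc1ccc(N2C(=O)COc3ccc(-c4cnc5ccccc5c4)cc32)cc1`: in a functional assay on HeLa cells (Homo sapiens) for antiproliferative activity, read by MTT assay, with a stated time of 72 h (a higher number here means a weaker inhibitor, a lower number a stronger inhibitor), compound 1 gives > 40000 nM, which is a limit of the assay rather than a number.
Compound 2 `O=C1COc2ccc(-c3cnc4ccccc4c3)cc2N1c1ccccc1`: compound 2 gives > 40000 nM, again a limit.
Compound 3 `O=C1COc2ccc(-c3ccc(O)cc3)cc2N1`: compound 3 gives > 40000 nM, also a limit.

Every value shown sits at the same limit (the limit of > 40000 nM in this assay, at which 3 of the 3 values shown sit), so compound 2 stands at that limit and nowhere more precise on the numbers shown. Going by the values given here, the only measured step, a step that the two limits leave unreadable from compound 1 to compound 2, cannot be read in size because the values at both of its ends are limits (the limit of > 40000 nM in this assay, at which 3 of the 3 values shown sit).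

Compound 4 `O=C1COc2ccc(-c3cnc4ccccc4c3)cc2N1c1ccc(Cl)cc1` differs from compound 2 by chloro in place of hydrogen on an aromatic carbon. Among the compounds with values here, no measured step involves a chloro group, and the one step that exists, a step that the two limits leave unreadable from compound 1 to compound 2, gives no readable size, so the data offer no basis for expecting a change in this assay in either direction beyond the scatter. Compound 4 is expected to give about 60000 nM, within a range from 20000 nM to 200000 nM, and most likely to be reported as a limit again. The step is expected to be a step that the limit leaves unreadable from compound 2 to compound 4.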

Compound 4, half-maximal inhibitory concentration: > 40000 nM
Compound 4: no number, only a limit (the forecaster's own chance of this, stated with the estimate: 85%); the middle value does not contradict the limit.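

The steps from compound 1 and compound 2 to compound 4 cannot be read in size, because the values at both ends of each step are limits: the limit of > 40000 nM in this assay, at which 4 of the 4 values shown sit.

The compounds shown leave open whether hydrogen, methyl or chloro at this place makes any difference in this assay.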